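A few compounds are considered here, and "the series" means these few. Any claim that something is new, unique, unknown or untested is made for them only; others in the source may bear on it.

Compound 3 `CC(C)[C@@H]1CC[C@@H](C)C[C@@]12N(C)C(=O)[C@@H]1[C@H]3C(=O)N(c4ccc(Cl)cc4)C(=O)[C@H]3ON12` belongs to a small set sharing one core and differing only in the group on an amide-type nitrogen in a ring. In a functional assay, with a stated time of 20 min, tested at 0.5 mg/mL (a lower number here means a weaker effect, a higher number a stronger effect of the compound at the concentration tested), compound 3 gives 18.1%. Compound 1 `CC(C)[C@@H]1CC[C@@H](C)C[C@@]12N(C)C(=O)[C@@H]1[C@H]3C(=O)N(C)C(=O)[C@H]3ON12` gives 18.2%, and compound 2 `CC(C)[C@@H]1CC[C@@H](C)C[C@@]12N(C)C(=O)[C@@H]1[C@H]3C(=O)N(c4ccccc4)C(=O)[C@H]3ON12` gives 21.6%; the number for compound 3 is the lowest of the three, yet each gap is within the scatter. Compound 4 `Cc1ccc(N2C(=O)[C@H]3[C@H](ON4[C@@H]3C(=O)N(C)[C@@]43C[C@H](C)CC[C@H]3C(C)C)C2=O)c(C)c1` is not yet measured and differs from compound 3 by 2,4-dimethylphenyl in place of 4-chlorophenyl on an amide-type nitrogen in a ring. Among the compounds with values here, the steps that bear on this are a number 0.1 percentage points lower from compound 1 to compound 3 (within the scatter) and a number 3.5 percentage points lower from compound 2 to compound 3 (within the scatter), both within the scatter, so swapping the group on this nitrogen has moved the read-out little. Compound 4 is therefore expected to show a number 1.4 percentage points higher from compound 3 to compound 4 (within the scatter), no step beyond the scatter. The estimated value for compound 4 is 19.5%, between 10% and 30%.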

Compound 4, a percentage reported as activity, at one concentration (the size of the read-out at that concentration, not a potency): 49.9%
Beside the measured number, compound 4's estimate is 30.4 percentage points below it; the whole stated range lies below it.
By their numbers in this assay, from the lowest: compounds 3, 1 and 2 (each within the scatter of the next); then compound 4.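

This nitrogen is less indifferent to its group than methyl, phenyl and 4-chlorophenyl suggested: in this assay the 2,4-dimethylphenyl group gives a number 31.8 percentage points higher from compound 3 to compound 4 (beyond the scatter) and a number 28.3 percentage points higher from compound 2 to compound 4 (beyond the scatter) and also a number 31.7 percentage points higher from compound 1 to compound 4 (beyond the scatter). Carrying an aromatic ring is not enough for this rise, since compound 2 and compound 3 each carry one without it. Nothing measured here gives a reason for the rise. Still open, going by these compounds, is whether both methyl groups are needed, which 2-methylphenyl and 4-methylphenyl would test. Also open, on these data alone, is how a benzyl group or an aminophenyl group would behave here.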